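Removing the 3-methylbut-2-en-1-yl group: cytotoxicity working notes

This account rests on a few compounds, and the source may have more. Where it says the series, first, only, none or still open, it means among the compounds named here.

Compound 1 `COc1cc(O)c(C(=O)/C=C/c2cccc(N3CCNCC3)c2)c(OC)c1` and compound 2 `COc1cc(OC)c(C(=O)/C=C/c2cccc(N3CCNCC3)c2)c(O)c1CC=C(C)C` share a core and differ in one group only. In an ADME assay on MCF7-DOX cells (Homo sapiens) for cytotoxicity, read by MTT assay, with a stated time of 48 h (on this read-out higher numbers stand for weaker inhibition and lower numbers for stronger inhibition), compound 1 gives 99200 nM. In this assay compound 2 gives 99900 nM. The change from compound 2 to compound 1 is hydrogen in place of 3-methylbut-2-en-1-yl on an aromatic carbon and it made a 1.0-fold lower number from compound 2 to compound 1 (0.00 log units; within the scatter). Both numbers lie near the top of the range covered here, and neither compound can be called more or less active than the other.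

Compound 3 `COc1cc(OC)c(C(=O)/C=C/c2ccc(N3CCN(C(=O)OC(C)(C)C)CC3)cc2)c(O)c1CC=C(C)C` carries a different core; how it differs from the core of compound 2 is not broken down here. In this assay compound 3 gives > 100000 nM, which is a limit of the assay and not a number. It sits at the limit of > 100000 nM in this assay, at which 1 of the 3 values shown sits.

Compound 4 `COc1cc(O)c(C(=O)/C=C/c2ccc(N3CCN(C(=O)OC(C)(C)C)CC3)cc2)c(OC)c1` is obtained from compound 3 by hydrogen in place of 3-methylbut-2-en-1-yl on an aromatic carbon, the same change that led from compound 2 to compound 1, at a place described in the same words. Compound 4 is expected to show a number no higher from compound 3 to compound 4 (the limit leaves the size open). That expectation rests on the step of a 1.0-fold lower number from compound 2 to compound 1 (0.00 log units; within the scatter) and on compound 3 standing at the limit of > 100000 nM in this assay, at which 1 of the 3 values shown sits, which together leave little room for a real move in either direction. For compound 4 in this assay the estimate is 100000 nM, with a range from 55000 nM to 200000 nM, and a limit rather than a number is the more likely outcome.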

Compound 4, half-maximal inhibitory concentration: 47300 nM
Compound 4: the middle estimate sits 2.1-fold (0.33 log units) above what was measured, outside the stated range (below it).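

In this assay, hydrogen in place of 3-methylbut-2-en-1-yl on an aromatic carbon gave an at least 2.1-fold lower number from compound 3 to compound 4 (0.32 log units; beyond the scatter), so on this core the change is followed by a lower number, and the step lies beyond the scatter. The value of compound 3, > 100000 nM, is a limit of the assay and not a number, so the step has a lower bound and no fixed size. The two cores therefore do not show that the change carries over unaltered, nor do they show that its result depends on the core: the same change on two cores in this assay, a 1.0-fold lower number (0.00 log units; within the scatter) from compound 2 to compound 1 and an at least 2.1-fold lower number (0.32 log units; beyond the scatter) from compound 3 to compound 4; the limit leaves it open whether they differ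

Still open, from the compounds shown here alone, is how far compound 3 really lies from compound 4, and whether the lower number on that core belongs to the removal of 3-methylbut-2-en-1-yl alone or would also follow from other groups at the same aromatic carbon, ortho to a hydroxy group and ortho to a methoxy group. The compounds shown also leave open what a methyl group, a longer chain, an amine or a carboxylic acid at that place would do to the number on either core.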